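A few compounds are considered here, and "the series" means these few. Any claim that something is new, unique, unknown or untested is made for them only; others in the source may bear on it.

Compound 1 `N#Cc1ccc(N2CCCc3c(-c4cccnc4)cccc32)cc1C(F)(F)F`: 12300 nM
Compound 2 `CCN(c1ccc(C#N)c(Cl)c1)c1cc(-c2cnc3ccccc3c2)ccc1C`: "not determined" (no result reported)
Compound 3 `CCN(c1ccc(C#N)c(Cl)c1)c1cc(-c2ccco2)ccc1C`: > 30000 nM

In a functional assay on CWR22R cells (Homo sapiens) for antiproliferative activity, read by CCK-8 assay, with a stated time of 6 days (a lower number here means a stronger inhibitor, a higher number a weaker inhibitor), compound 3 has no number at all, only a limit, > 30000 nM. Compound 2 has no result. Compound 1 gives 12300 nM, a weak but measurable value on a different core. Compound 4 `CCN(c1ccc(C#N)c(Cl)c1)c1cc(-c2cccnc2)ccc1C` differs from compound 3 in one place: pyridin-3-yl in place of furan-2-yl on an aromatic carbon. Within the data shown here, no measured pair shows this change on the shared core, so the step can only be guessed. Compound 4 is expected to gain somewhat in this assay, because compound 1 carries the same pyridin-3-yl and gives 12300 nM. Compound 4 is thus estimated at 18000 nM, within 5000 nM to 40000 nM, an expected step of an at least 1.6-fold lower number from compound 3 to compound 4 (0.22 log units; that floor lies within the scatter).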

Compound 4, half-maximal inhibitory concentration: 2000 nM
The estimate for compound 4 lay 9.0-fold (0.95 log units) above the measured number; measured number below the stated range.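

On the aromatic carbon para to a methyl group, the shared core proves sensitive to which ring it carries: in this assay, the change gives an at least 15-fold lower number from compound 3 to compound 4 (1.17 log units; beyond the scatter). That step is only a minimum, because compound 3 has a limit rather than a number: the limit of > 30000 nM in this assay, at which 1 of the 4 values shown sits. Both groups count one aromatic ring with one hetero atom and one hydrogen-bond acceptor, so these counts alone do not separate them.

Going by these compounds, whether pyridin-4-yl or an amine on this carbon would match pyridin-3-yl remains open.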